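The compounds below may be only part of what the source reports. "The series", "measured", "known", "first", "only" and "open" are said of these compounds alone.

Compound 1 `CCNC1=NS(=O)(=O)c2cccc(Cl)c2N1`: 90400 nM
Compound 2 `CCNC1=NS(=O)(=O)c2ccc(Cl)cc2N1`: 54800 nM

Both compounds were tested in a functional assay on aorta (Rattus norvegicus) for inhibition; a higher number here means that more compound is needed for the effect, a lower number that less compound is needed. There compound 2 gives 54800 nM and compound 1 gives 90400 nM. These two numbers lie within the usual scatter of each other, so neither stands apart.

Compound 3 `CCCNC1=NS(=O)(=O)c2ccc(Cl)cc2N1` keeps the core of compound 2 and changes only the chain: methyl in place of hydrogen on a saturated chain carbon, two bonds along the chain from an amine nitrogen. This is methyl in place of hydrogen on a saturated chain carbon, two bonds along the chain from an amine nitrogen, so that ethylamino becomes propylamino. No measured pair among these compounds shows what such a change does, which leaves the expectation poorly anchored. Starting from compound 2 at 54800 nM, a small step towards a lower number is expected in this assay, no larger than the scatter. The estimated change is a 1.6-fold lower number from compound 2 to compound 3 (0.19 log units; within the scatter). The estimate for compound 3 is 35000 nM, with an expected range from 12000 nM to 100000 nM.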

Compound 3, half-maximal effective concentration: 73200 nM
For compound 3 the middle estimate is 2.1-fold (0.32 log units) below the measured one; measured number inside the range.
By their numbers in this assay, from the lowest: compounds 2, 3 and 1 (each within the scatter of the next).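

In this assay, among the compounds shown here, the change from ethylamino to propylamino gives a 1.3-fold higher number from compound 2 to compound 3 (0.13 log units; within the scatter), and this is the first measured pair to show what this change does. Methyl in place of hydrogen on a saturated chain carbon, two bonds along the chain from an amine nitrogen, therefore produces no step that can be told apart from repeat measurement, and compound 2 and compound 3 read as equals in this assay. Nothing among the data explains this result, and no measurement of any property of the chain bears on it.

This single pair says nothing about how far the chain can be taken, so a longer chain such as butylamino, a branched isopropylamino or a ring-bearing cyclopropylmethylamino could still stay level with compound 2 or move clear of it. For the compounds shown here, it also remains open whether propylamino would behave the same way on the core of compound 1, where the chlorine stands elsewhere, since the one step available was read only on the core of compound 2.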